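Para substituent swap on the urea aryl ring of a thieno-pyrimidine

A few compounds are considered here, and "the series" means these few. Any claim that something is new, unique, unknown or untested is made for them only; others in the source may bear on it.

Compound 1 `O=C(Nc1ccccc1)Nc1nnc(Sc2ncnc3scc(-c4ccncc4)c23)s1`: 19300 nM
Compound 2 `O=C(Nc1cccc(C(F)(F)F)c1)Nc1nnc(Sc2ncnc3scc(-c4ccncc4)c23)s1`: 22400 nM
Compound 3 `COc1ccc(NC(=O)Nc2nnc(Sc3ncnc4scc(-c5ccncc5)c34)s2)cc1`: 16900 nM

In a functional assay on HUVEC cells (Homo sapiens) for antiproliferative activity, read by MTT assay, with a stated time of 48 h (a lower number here means a stronger inhibitor, a higher number a weaker inhibitor), compound 3 gives the lowest of the three numbers, though its gaps to compound 1 and compound 2 both fall within the scatter. Compound 4 `O=C(Nc1ccc(F)cc1)Nc1nnc(Sc2ncnc3scc(-c4ccncc4)c23)s1` differs from compound 3 in one place: fluoro in place of methoxy on an aromatic carbon, on an aromatic carbon para to a large group. Two earlier steps bear on this: a 1.1-fold lower number from compound 1 to compound 3 (0.06 log units; within the scatter) and a 1.3-fold lower number from compound 2 to compound 3 (0.12 log units; within the scatter), both within the scatter, so substituents on this ring have so far left this assay unmoved. Compound 4 is therefore expected to give 19000 nM, between 10000 nM and 36000 nM, meaning an estimated step of a 1.1-fold higher number from compound 3 to compound 4 (0.05 log units; within the scatter) that stays within the scatter.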

Compound 4, half-maximal inhibitory concentration: 28300 nM
Compound 4: middle estimate off by 1.5-fold (0.17 log units), on the low side; measured number inside the range.
By their numbers in this assay, from the lowest: compounds 3, 1, 2 and 4 (each within the scatter of the next).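

With fluoro on this aromatic carbon, this assay again stays unmoved: a 1.5-fold higher number from compound 1 to compound 4 (0.17 log units; within the scatter) for fluoro in place of hydrogen, and a 1.3-fold higher number from compound 2 to compound 4 (0.10 log units; within the scatter) for 4-fluorophenyl in place of 3-(trifluoromethyl)phenyl. Fluoro in place of methoxy gives the largest step yet on this ring, a 1.7-fold higher number from compound 3 to compound 4 (0.22 log units; within the scatter), and even that does not leave the scatter. No evidence here speaks to why these steps stay so small. The compounds shown leave open whether an amine or a carboxylic acid on this ring would move the number beyond the scatter.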